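This account rests on a few compounds, and the source may have more. Where it says the series, first, only, none or still open, it means among the compounds named here.

The measured compounds are:
compound 1, `CNC(=O)c1cc(Oc2ccc(/C=C/c3ccncc3)cc2)ccn1`, with 13200 nM in a functional assay on A549 cells (Homo sapiens) for antiproliferative activity, read by CCK-8 assay, with a stated time of 48 h; a higher number here means a weaker inhibitor, a lower number a stronger inhibitor
compound 2, `COc1ccc(CNC(=O)c2cc(Oc3ccc(/C=C/c4ccncc4)cc3)ccn2)cc1`, with 19300 nM
compound 3, `O=C(NCc1ccc(F)cc1)c1cc(Oc2ccc(/C=C/c3ccncc3)cc2)ccn1`, with 18200 nM

All three share one core and differ only in the group carried by the amide-type nitrogen. Compound 3 stands close to both companions: its number and those of compound 1 and compound 2 all lie within the usual scatter of one another, so none of the three can be set apart as stronger or weaker. The three steps say the same: a 1.5-fold higher number from compound 1 to compound 2 (0.16 log units; within the scatter), a 1.4-fold higher number from compound 1 to compound 3 (0.14 log units; within the scatter), and a 1.1-fold lower number from compound 2 to compound 3 (0.03 log units; within the scatter).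

Compound 4, `CC(C)NC(=O)c1cc(Oc2ccc(/C=C/c3ccncc3)cc2)ccn1`, has not yet been measured. Relative to compound 3 the change is isopropyl in place of 4-fluorobenzyl on an amide-type nitrogen. The step that bears most directly on it is a 1.4-fold higher number from compound 1 to compound 3 (0.14 log units; within the scatter), where the same amide-type nitrogen carried either hydrogen or 4-fluorobenzyl without a difference beyond the scatter; the change from methoxy to fluoro in a 1.1-fold lower number from compound 2 to compound 3 (0.03 log units; within the scatter) was likewise within the scatter. Nothing measured here suggests that the group on this nitrogen moves the number noticeably, so no step beyond the scatter is expected in either direction for compound 4. Compound 4 is therefore expected to give about 15000 nM in this assay, within a range from 7000 nM to 32000 nM. The expected step from compound 3 is a 1.2-fold lower number from compound 3 to compound 4 (0.08 log units; within the scatter).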

Compound 4, half-maximal inhibitory concentration: 20600 nM
Beside the measured number, compound 4's estimate is 1.4-fold (0.14 log units) below it; low and high end bracket the measured number.
By their numbers in this assay, from the lowest: compounds 1, 3, 2 and 4 (each within the scatter of the next).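

Replacing the ring-bearing 4-fluorobenzyl with the ring-free isopropyl, a much smaller group, gives a 1.1-fold higher number from compound 3 to compound 4 (0.05 log units; within the scatter), and replacing 4-methoxybenzyl with isopropyl gives a 1.1-fold higher number from compound 2 to compound 4 (0.03 log units; within the scatter), so the aromatic ring on this group is not needed for the level seen in this small set. Isopropyl in place of methyl gives a 1.6-fold higher number from compound 1 to compound 4 (0.19 log units; within the scatter), which means that in this assay all four groups on this amide-type nitrogen, from small chains to substituted benzyl groups, remain indistinguishable. The information available offers no explanation for this lack of separation.

These compounds leave open whether a group of a different kind on this nitrogen, such as one carrying an amine or a carboxylic acid, or a longer chain, would shift the number beyond the scatter. Since the rest of the shared core stays the same throughout, they also leave open whether a change elsewhere, such as a substituent on the pyridine or a replacement of the carbon-carbon double bond, would matter more than this position does.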